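Swapping a cyclopentyl amide for a dihydroxypropyl amide

The source may hold more compounds than are shown below. What is called first, only, known or untested is meant among the compounds shown, and "the series" means these compounds.

Measured compounds:
- compound 1, `N=c1oc2ccc(Br)cc2cc1C(=O)NC1CCCCC1`, 10%
- compound 2, `COCCNC(=O)c1cc2cccc(OC)c2oc1=N`, 43%
- compound 3, `N=c1oc2ccc(Br)cc2cc1C(=O)NC1CCCC1`, 28%

All three were tested in an assay on HEK293 cells for displacement of a labelled ligand from adenosine receptor A2b (Homo sapiens), read by scintillation counting, with a stated time of 30 min, tested at 10 uM; on this read-out lower numbers stand for less inhibition and higher numbers for more inhibition at the one concentration tested (going by the name of the read-out). Compound 3 stands second highest of the three; compound 2 sits above it, and compound 1 sits below it, both gaps beyond the usual scatter.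

Within the data shown here, the only step that changes one place is the one from compound 1 to compound 3, where cyclopentyl replaces cyclohexyl on the amide-type nitrogen, and it gives a number 18 percentage points higher from compound 1 to compound 3 (beyond the scatter). Compound 4, `N=c1oc2ccc(Br)cc2cc1C(=O)NCC(O)CO`, differs from compound 3 in the same place: 2,3-dihydroxypropyl in place of cyclopentyl on an amide-type nitrogen. Among the measured compounds shown here, the measured step says only that shrinking the ring helped modestly; it does not show what an open chain with two hydroxyls does. For the measured compounds named here, compound 2 carries an open chain on its amide nitrogen and gives the highest number, but its core also differs, so no step is drawn from it.

For compound 4 the expected number is therefore near that of compound 3, with wide uncertainty: 30% (range 10% to 50%), an expected step of a number 2 percentage points higher from compound 3 to compound 4 (within the scatter).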

Compound 4, a percentage reported as inhibition, at one concentration (the size of the read-out at that concentration, not a potency): 4%
Compound 4: middle estimate off by 26 percentage points, on the high side; measured number outside the range, below it.
By their numbers in this assay, from the lowest: compounds 4 and 1 (each within the scatter of the next); then compound 3; then compound 2.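

In this assay, the group on this amide-type nitrogen matters beyond its heavy-atom count: 2,3-dihydroxypropyl and cyclopentyl each hold 5 heavy atoms, yet the swap gives a number 24 percentage points lower from compound 3 to compound 4 (beyond the scatter). Set against cyclohexyl, the same open chain gives a number 6 percentage points lower from compound 1 to compound 4 (within the scatter), so these two very different groups cannot be told apart here, and cyclopentyl alone stands out, with a number 18 percentage points higher from compound 1 to compound 3 (beyond the scatter). Nothing measured here says why the swap to the open chain with two hydroxyls changes the number.

Still open, as far as these compounds go, is whether the loss follows from the hydroxyls or from giving up the ring. A plain propyl chain or a hydroxycyclopentyl group on the core of compound 3 would separate those two, and a cyclobutyl ring would test whether shrinking the ring further continues the step from cyclohexyl to cyclopentyl.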